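A few compounds are considered here, and "the series" means these few. Any claim that something is new, unique, unknown or untested is made for them only; others in the source may bear on it.

Working notes on the series. In a functional assay on HeLa cells (Homo sapiens) for cytotoxicity, read by MTT assay, with a stated time of 72 h (a lower number here means a stronger inhibitor, a higher number a weaker inhibitor), compound 1 `Cc1cccc(CSc2cc(Cl)c(C)cc2S(=O)(=O)/N=C(\N)n2nccc2-c2ccccc2)c1` gives 8000 nM, the higher of the two numbers recorded so far; compound 2 `Cc1cc(-c2ccccc2)n(/C(N)=N/S(=O)(=O)c2cc(C)c(Cl)cc2SCc2cccc3ccccc23)n1` gives 3000 nM, and the gap between these two lies beyond the scatter. Compound 3 `Cc1cc(S(=O)(=O)/N=C(\N)n2nccc2-c2ccccc2)c(SCc2ccccc2)cc1Cl` is compound 1 with hydrogen in place of methyl on an aromatic carbon. Going by the values given here, no measured pair shows this change, so nothing in the numbers fixes its size; a step within the scatter, in either direction, is expected. For compound 3 the estimate in this assay is 9000 nM, range 4000 nM to 20000 nM, expected to mean a step of a 1.1-fold higher number from compound 1 to compound 3 (0.05 log units; within the scatter).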

Compound 3, half-maximal inhibitory concentration: 5000 nM
Compound 3: the middle estimate sits 1.8-fold (0.26 log units) above what was measured, within the range that was stated.
By their numbers in this assay, from the lowest: compounds 2, 3 and 1 (each within the scatter of the next, the first and the last beyond it).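

In this assay, hydrogen in place of methyl on an aromatic carbon, meta to a large group, now has a measured size: a 1.6-fold lower number from compound 1 to compound 3 (0.20 log units; within the scatter). At this position, 3-methylbenzyl and benzyl therefore cannot be told apart in this assay, and the methyl is not required for the activity seen here. No available evidence explains this result.

From the compounds shown here alone, whether a methoxy group, an amine or a carboxylic acid at this position would give a step beyond the scatter remains open. So does whether the same change would give a similar step in another compound of the series.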